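Swapping a cyclohexylamino for a cyclopentylsulfanyl

The source may report more compounds than this note shows. Statements on the series, on what has been measured and on what is new or still open speak of the compounds shown alone.

Compound 1 `Nc1nc(NC2CCCCC2)c2ncn(/C=C3/CC3(CO)CO)c2n1` carries a cyclohexylamino group on the shared core. In an ADME assay on Akata cells (Homo sapiens) for cytotoxicity, with a stated time of 7 days (a lower number here means that less compound is tolerated, a higher number that more compound is tolerated), compound 1 gives only a limit, namely > 24000 nM as the top concentration tested. Two close relatives were run in the same way. Compound 2 `CCCCCCSc1nc(N)nc2c1ncn2/C=C1/CC1(CO)CO` bears a hexylsulfanyl group in place of the cyclohexylamino group, and in this assay compound 2 likewise stops at a limit of > 20000 nM without a number. Compound 3 `Nc1nc(OCc2ccccc2)c2ncn(/C=C3/CC3(CO)CO)c2n1` bears a benzyloxy group there, and in this assay compound 3 also returns a limit of > 20000 nM rather than a value. The steps between these three therefore cannot be sized: a step that the two limits leave unreadable from compound 1 to compound 2, a step that the two limits leave unreadable from compound 1 to compound 3 and a step that the two limits leave unreadable from compound 2 to compound 3 all stay unreadable. What the three do share is the limit of > 20000 nM in this assay, at which 2 of the 3 values shown sit, together with the limit of > 24000 nM in this assay, at which 1 of the 3 values shown sits, so none of them harmed the cells within the tested range.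

Compound 4 `Nc1nc(SC2CCCC2)c2ncn(/C=C3/CC3(CO)CO)c2n1` changes the same position once more: cyclopentylsulfanyl in place of cyclohexylamino on an aromatic carbon. Going by the values given here, no measured step offers a readable size to lean on, so the expectation rests on compound 1 sitting at > 24000 nM and on its relatives sitting at the same kind of ceiling. Compound 4 is expected to show no step beyond the scatter, a step that the limit leaves unreadable from compound 1 to compound 4, and is estimated at 25000 nM with a range from 10000 nM to 60000 nM, most likely again as a limit.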

Compound 4, half-maximal cytotoxic concentration: > 20000 nM
Compound 4: a limit, no number; the forecaster's own chance of this, stated with the estimate: 80%; the middle value lies beyond the limit too.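

Going by these compounds alone, compound 4 also ends at a limit in this assay, as do compound 1, compound 2 and compound 3, so no step from compound 4 to any of these three can be read. The compounds shown leave open at what concentration any of them would reach half-maximal cytotoxicity, and whether changing the group at this position alters that concentration.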